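Benzylpiperidine benzoxazolone series: aryl substitution and sigma-1 binding

A few compounds are considered here, and "the series" means these few. Any claim that something is new, unique, unknown or untested is made for them only; others in the source may bear on it.

Measured so far:
compound 1 `O=c1oc2ccccc2n1CC1CCN(Cc2ccccc2)CC1` — 3.6 nM
compound 2 `O=c1oc2ccccc2n1CC1CCN(Cc2ccccc2F)CC1` — 23 nM

In an assay on membranes from liver for displacement of a labelled ligand from Sigma non-opioid intracellular receptor 1 (Rattus norvegicus) (a higher number here means a weaker inhibitor, a lower number a stronger inhibitor), compound 1 gives 3.6 nM and compound 2 gives 23 nM. Compound 2 therefore stands at the higher of the two numbers, separated from compound 1 by a 6.4-fold higher number from compound 1 to compound 2 (0.81 log units; beyond the scatter), which arises from fluoro in place of hydrogen on an aromatic carbon.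

Compound 3 `Cc1ccc(CN2CCC(Cn3c(=O)oc4ccccc43)CC2)c(C)c1` carries 2,4-dimethylphenyl in place of 2-fluorophenyl on a saturated chain carbon bound to an amine nitrogen in a ring. Within the data shown here, no measured step covers this exchange: the only step known, a 6.4-fold higher number from compound 1 to compound 2 (0.81 log units; beyond the scatter), concerns a single fluoro entering the unsubstituted ring, and nothing shows how two methyl groups behave on the same ring. The one point of reference is that compound 1, with the unsubstituted ring, sits lower than compound 2 in this assay; whether a dimethyl ring returns toward that number or moves further away is not settled.

On that footing compound 3 is estimated at 10 nM, with a range from 3 nM to 40 nM, the expected step being a 2.3-fold lower number from compound 2 to compound 3 (0.36 log units; beyond the scatter), with wide uncertainty either way.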

Compound 3, inhibition constant: 30 nM
Estimate against measurement, compound 3: 3.0-fold (0.48 log units) below; low and high end bracket the measured number.
By their numbers in this assay, from the lowest: compound 1; then compounds 2 and 3 (each within the scatter of the next).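

In this assay, 2,4-dimethylphenyl in place of 2-fluorophenyl on a saturated chain carbon bound to an amine nitrogen in a ring gives a 1.3-fold higher number from compound 2 to compound 3 (0.12 log units; within the scatter), so a ring with two methyl groups cannot be told apart from a ring with a single fluoro. Against the phenyl of compound 1, the same dimethyl ring gives an 8.3-fold higher number from compound 1 to compound 3 (0.92 log units; beyond the scatter); the higher number is therefore not confined to fluoro, and among these three compounds both substituted rings stand beyond the scatter from the unsubstituted one. Nothing available accounts for the two substituted rings reading alike.

Open, from the compounds shown here alone, is whether a single methyl group on the ring would read like the two in compound 3, or whether one of the two carries the whole step. Also open, going by these compounds, is how a ring bearing a methoxy group or a nitrile would read.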